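Imidazolidinone headgroup variation in a thiophene sulfonylcarbamate series

The compounds below may be only part of what the source reports. "The series", "measured", "known", "first", "only" and "open" are said of these compounds alone.

Measured compounds in an assay on membranes from uterus for displacement of a labelled ligand from Angiotensin type II receptor (Sus scrofa), with a stated time of 1.5 h; on this read-out higher numbers stand for weaker inhibition and lower numbers for stronger inhibition:
- compound 1 `CCCCOC(=O)NS(=O)(=O)c1sc(CC(C)C)cc1-c1ccc(CN2CCN(C)C2=O)cc1`: 16.5 nM
- compound 2 `CCCCOC(=O)NS(=O)(=O)c1sc(CC(C)C)cc1-c1ccc(Cn2ccc(C(F)(F)F)n2)cc1`: 9.5 nM
- compound 3 `CCCCOC(=O)NS(=O)(=O)c1sc(CC(C)C)cc1-c1ccc(CN2C(=O)N(C)C(C)(C)C2=O)cc1`: 3.6 nM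

Compound 3 gives the lowest number of the three; its separation from compound 2 is a 2.6-fold lower number from compound 2 to compound 3 (0.42 log units; beyond the scatter) and from compound 1 is a 4.6-fold lower number from compound 1 to compound 3 (0.66 log units; beyond the scatter), both beyond the scatter. Compound 4 `CCCCOC(=O)NS(=O)(=O)c1sc(CC(C)C)cc1-c1ccc(CN2C(=O)CN(C)C2=O)cc1` differs from compound 3 only in the headgroup: 3-methyl-2,5-dioxoimidazolidin-1-yl in place of 3,4,4-trimethyl-2,5-dioxoimidazolidin-1-yl on a saturated chain carbon bound to an aromatic carbon. For the measured compounds named here, no measured step isolates this change; the step of a 4.6-fold lower number from compound 1 to compound 3 (0.66 log units; beyond the scatter) mixes the added carbonyl with the added methyls, so it bears only loosely. A small rise in the number in this assay is expected for compound 4, roughly a 1.8-fold higher number from compound 3 to compound 4 (0.26 log units; within the scatter), possibly within the scatter. Compound 4 is therefore estimated at 6.5 nM, with a range of 2.5 nM to 16 nM.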

Compound 4, inhibition constant: 68.6 nM
The estimate for compound 4 lay 11-fold (1.02 log units) below the measured number; the whole stated range lies below it.
By their numbers in this assay, from the lowest: compound 3; then compounds 2 and 1 (each within the scatter of the next); then compound 4.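

For the compounds shown here, removing the extra methyls from the 3,4,4-trimethyl-2,5-dioxoimidazolidin-1-yl headgroup gives the largest step so far (a 19-fold higher number from compound 3 to compound 4 (1.28 log units; beyond the scatter)), so the headgroup's effect depends heavily on those methyls. Without them, the dione headgroup also falls behind the trifluoromethylpyrazole of compound 2 (a 7.2-fold higher number from compound 2 to compound 4 (0.86 log units; beyond the scatter)) and the single-carbonyl ring of compound 1 (a 4.2-fold higher number from compound 1 to compound 4 (0.62 log units; beyond the scatter)), so the second carbonyl alone does not give the low number of compound 3. No measurement available here bears on the cause of this loss.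

Still open, from the compounds shown here alone, is whether a single extra methyl, or two ethyl groups in place of the methyls, would restore the number.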